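The source may report more compounds than this note shows. Statements on the series, on what has been measured and on what is new or still open speak of the compounds shown alone.

In a functional assay on HUVEC cells (Homo sapiens) for antiproliferative activity, read by MTT assay, with a stated time of 24 h (a lower number here means a stronger inhibitor, a higher number a weaker inhibitor), three compounds with a shared core have been tested. Compound 1 `COc1cccc(C(=O)Oc2ccc3c(=O)c(-c4cc(OC)c(OC)cc4OC)coc3c2)c1` reads > 10000 nM, which is a limit of the assay and not a number. Compound 2 `COc1cc(OC)c(-c2coc3cc(OCC(=O)c4cccc(C(F)(F)F)c4)ccc3c2=O)cc1OC` reads > 10000 nM, which is also a limit. Going by the values given here, compound 3 `COc1cc(OC)c(-c2coc3cc(OCc4cccc(F)c4)ccc3c2=O)cc1OC`, with a 3-fluorobenzyl group on an oxygen, gives 5300 nM, the only actual number so far. The other two results mark (the limit of > 10000 nM in this assay, at which 2 of the 3 values shown sit).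

Compound 4 `COc1cc(OC)c(-c2coc3cc(OCc4cccc(Br)c4)ccc3c2=O)cc1OC` differs from compound 3 in a single place: bromo in place of fluoro on an aromatic carbon. Fluoro leaves and bromo enters at that place, meta to a large group.

Two measured steps end at compound 3: an at least 1.8-fold lower number from compound 1 to compound 3 (0.27 log units; that floor lies within the scatter), and an at least 1.8-fold lower number from compound 2 to compound 3 (0.27 log units; that floor lies within the scatter). Both replace a larger part of the group on the oxygen, and neither swaps fluoro for bromo, so they bear only loosely on this change. Among the compounds with values here, no measured pair shows this swap directly.

The expectation therefore starts from compound 3 at 5300 nM, with no step beyond the scatter expected in this assay. The estimated change is a 1.3-fold lower number from compound 3 to compound 4 (0.12 log units; within the scatter), which would stay within that scatter. For compound 4 the expected value is 4000 nM, with an estimated range from 1300 nM to 10000 nM.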

Compound 4, half-maximal inhibitory concentration: > 10000 nM
Compound 4 ended at the assay's limit; the forecaster's own chance of this, stated with the estimate: 20%; middle value at least 2.5-fold (0.39 log units) from the limit.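

Going by these compounds alone, this is the only pair in this assay in which nothing changes except bromo in place of fluoro on the aromatic carbon, and it gives an at least 1.8-fold higher number from compound 3 to compound 4 (0.27 log units; that floor lies within the scatter). The earlier steps shown here to compound 3 replaced a larger part of the group on the oxygen, whereas here the (3-fluorobenzyl)oxy group becomes (3-bromobenzyl)oxy and the reading of compound 3 is not kept, although the size of the step is only a floor and that floor does not clear the usual scatter. The steps from compound 1 and from compound 2 to compound 4 cannot be read, because both ends of each step sit at the same limit: the limit of > 10000 nM in this assay, at which 3 of the 4 values shown sit.

The compounds shown leave open whether chloro, methyl or methoxy at this place, or a plain hydrogen, would give a number at all, and so whether fluoro is needed for the reading of compound 3. They also leave open how far past the limit compound 4 lies, and whether an amine or a carboxylic acid on this ring would bring a stronger reading.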